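Working notes: benzyl substitution on two related cores

The source may hold more compounds than are shown below. What is called first, only, known or untested is meant among the compounds shown, and "the series" means these compounds.

Measured values in a functional assay on BXPC-3 cells (Homo sapiens) for inhibition, read by MTT assay, with a stated time of 48 h; a lower number here means a stronger inhibitor, a higher number a weaker inhibitor:

Compound 1 `Cc1[nH]c2ccccc2c1C1CC(c2ccncc2)=NO1`: 95500 nM
Compound 2 `COc1ccc2c(C3CC(c4ccncc4)=NO3)c[nH]c2c1`: 9500 nM
Compound 3 `Cc1c(C2CC(c3ccncc3)=NO2)c2ccccc2n1Cc1ccc(Cl)cc1`: 13500 nM

Compound 1 and compound 3 share a core and differ only by 4-chlorobenzyl in place of hydrogen on an aromatic nitrogen. That change gave a 7.1-fold lower number from compound 1 to compound 3 (0.85 log units; beyond the scatter). Compound 2 carries a different core; how it differs from compound 1 is not broken down here. In this assay compound 2 gives the lowest of the three numbers, but its gap to compound 3 lies within the scatter, so no order between compound 2 and compound 3 is claimed; only its gap to compound 1 lies beyond the scatter.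

Compound 4 `COc1ccc2c(C3CC(c4ccncc4)=NO3)cn(Cc3ccc(Cl)cc3)c2c1` is not yet measured in this assay. It differs from compound 2 by 4-chlorobenzyl in place of hydrogen on an aromatic nitrogen. Going by the values given here, this is the same kind of change as the one from compound 1 to compound 3, but not the same: in compound 3 the aromatic nitrogen that takes the 4-chlorobenzyl group is next to the ring atom that bears a methyl group, whereas in compound 4 no such group stands there, and the surrounding core is a different one.

The expectation for compound 4 rests on the step seen once, a 7.1-fold lower number from compound 1 to compound 3 (0.85 log units; beyond the scatter), tempered by the fact that it was observed on another core. Compound 4 is expected to give a step of a 3.2-fold lower number from compound 2 to compound 4 (0.50 log units; beyond the scatter) from compound 2. Compound 4 is thus estimated at 3000 nM, with a plausible range from 800 nM to 12000 nM.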

Compound 4, half-maximal inhibitory concentration: > 100000 nM
Compound 4 ended at the assay's limit (the forecaster's own chance of this, stated with the estimate: 5%); middle value at least 33-fold (1.52 log units) away from the limit.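

Compound 4 stands at a limit of this assay, which is not a number: the limit of > 100000 nM in this assay, at which 1 of the 4 values shown sits. On the core of compound 2, 4-chlorobenzyl in place of hydrogen on an aromatic nitrogen gives an at least 10-fold higher number from compound 2 to compound 4 (1.02 log units; beyond the scatter), so in this series the change does not carry from one core to the other, even in direction: the same change on two cores in this assay, a 7.1-fold lower number (0.85 log units; beyond the scatter) from compound 1 to compound 3 and an at least 10-fold higher number (1.02 log units; beyond the scatter) from compound 2 to compound 4, at least 74-fold (1.87 log units) apart, beyond the scatter of two such steps. Going by these compounds alone, this shows that the result on the core of compound 1 cannot serve as a guide for the core of compound 2, but it does not show which difference between the two cores turns the step around, and with only one pair per core, no rule for any further core follows; the full size of the new step also stays unknown, as only its lower bound can be read.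

Left open is whether a different group on that aromatic nitrogen, such as an ethyl chain, an unsubstituted benzyl or a benzyl bearing a carboxylic acid or an amine, would follow compound 3 or compound 4. Also open, from the compounds shown here alone, is whether the methyl group of compound 1 or the methoxy group of compound 2, taken alone, decides the direction of the step.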